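A few compounds are considered here, and "the series" means these few. Any claim that something is new, unique, unknown or untested is made for them only; others in the source may bear on it.

Measured in a functional assay on HeLa cells (Homo sapiens) for antiproliferative activity, read by MTT assay, with a stated time of 48 h; on this read-out lower numbers stand for stronger inhibition and higher numbers for weaker inhibition:
- Compound 1 `COc1ccc2[nH]c(-c3cn(-c4ccccc4)nc3-c3ccc(F)cc3)nc2c1`: 7510 nM
- Compound 2 `Cc1ccc2[nH]c(-c3cn(-c4ccccc4)nc3-c3ccc(F)cc3)nc2c1`: 3630 nM

Of these two, compound 2 has the lower number, 3630 nM, which makes it the more active in this assay. The next compound, compound 3 `COc1ccc(-c2nn(-c3ccccc3)cc2-c2nc3cc(C)ccc3[nH]2)cc1`, keeps the core and the methyl group of compound 2 and changes one substituent: methoxy in place of fluoro on an aromatic carbon. This puts methoxy in place of fluoro on an aromatic carbon, para to a large group, so that 4-fluorophenyl becomes 4-methoxyphenyl.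

Within the data shown here, only one measured step bears on this: a 2.1-fold lower number from compound 1 to compound 2 (0.32 log units; beyond the scatter), with methyl in place of methoxy on an aromatic carbon. Among the measured compounds shown here, that modest step lies elsewhere in the molecule, and no measured step touches the fluoro group, so the guidance is weak. On that single step, a small rise in the number is expected, possibly no larger than the scatter. The expected change is a 1.2-fold higher number from compound 2 to compound 3 (0.09 log units; within the scatter). For compound 3 the estimated value is 4500 nM, with an expected range from 1600 nM to 12500 nM.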

Compound 3, half-maximal inhibitory concentration: 3290 nM
Compound 3: the middle estimate sits 1.4-fold (0.14 log units) above what was measured, within the range that was stated.
By their numbers in this assay, from the lowest: compounds 3 and 2 (each within the scatter of the next); then compound 1.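

In this assay, the change from 4-fluorophenyl to 4-methoxyphenyl gives a 1.1-fold lower number from compound 2 to compound 3 (0.04 log units; within the scatter), so with the methyl group on the shared core, these two groups cannot be told apart at this position. Among these compounds, this is the first reading at this position, as the earlier step, a 2.1-fold lower number from compound 1 to compound 2 (0.32 log units; beyond the scatter), concerned another place in the molecule, and it shows that a methoxy group, which brings a hydrogen-bond acceptor that the fluoro group lacks, is accommodated here with no change beyond the scatter. Nothing at hand explains why the two groups read alike in this series.

The compounds shown leave open whether this position stays as insensitive with other groups on this aromatic carbon, such as an amine, a carboxylic acid or a longer alkoxy chain, or with a plain phenyl ring in place of the substituted one. They also leave open whether the same exchange of fluoro for methoxy would read alike with a methoxy group rather than a methyl group on the core, since this change appears only once.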